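Changing the aryl group on the shared core of compound 2

The source may hold more compounds than are shown below. What is called first, only, known or untested is meant among the compounds shown, and "the series" means these compounds.

Of the compounds shown here, three sharing one core have been measured in a functional assay on the whole organism (strain Swiss) with Mus musculus as the target, in the maximal electroshock model, with a stated time of 0.5 h, at a dose of 100 mg/kg by the intraperitoneal route; a higher number here means a stronger effect of the compound at the dose given, a lower number a weaker effect. Compound 1, `COCC(C(=O)N1CCN(c2cccc(C(F)(F)F)c2)CC1)N1C(=O)CCC1=O`, gives 75%. Compound 3, `CCC(C(=O)N1CCN(c2cccc(C(F)(F)F)c2)CC1)N1C(=O)CCC1=O`, gives 50%. Compound 2, `CC(C(=O)N1CCN(c2ccc(Cl)cc2)CC1)N1C(=O)CCC1=O`, gives 25%. Compound 2 therefore stands lowest of the three; compound 3 lies nearest to it, and compound 1 lies furthest.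

Within the data shown here, the only step between measured compounds that differ in one place is a number 25 percentage points lower from compound 1 to compound 3 (beyond the scatter), and it concerns the chain, not the aryl group. Compound 4, `Cc1cccc(N2CCN(C(=O)C(C)N3C(=O)CCC3=O)CC2)c1`, differs from compound 2 by 3-methylphenyl in place of 4-chlorophenyl on an amine nitrogen in a ring. No measured step in this assay touches the aryl group, so nothing shown bears directly on this change, and the expectation for compound 4 rests on the value of compound 2 alone. The account therefore expects no step beyond the usual scatter, while leaving room for the spread seen across the three measured compounds.

Compound 4 is expected to give about 35% in this assay, within a range from 10% to 65%. That estimate means an expected change of a number 10 percentage points higher from compound 2 to compound 4 (within the scatter).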

Compound 4, a percentage reported as activity, at one dose (the size of the read-out at that dose, not a potency): 0%
Estimate against measurement, compound 4: 35 percentage points above; measured number below the stated range.
By their numbers in this assay, from the lowest: compound 4; then compound 2; then compound 3; then compound 1.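

In this assay the aryl group on the amine nitrogen in the ring is now shown to matter for the read-out: 3-methylphenyl in place of 4-chlorophenyl gives a number 25 percentage points lower from compound 2 to compound 4 (beyond the scatter) and is of the same size as the one step known so far on the chain, a number 25 percentage points lower from compound 1 to compound 3 (beyond the scatter) in the same assay. The two groups match in everything counted, with 7 heavy atoms each, one six-membered aromatic ring of carbon only and no hydrogen-bond donors or acceptors, so a swap that leaves these counts unchanged can still move the number beyond the scatter. Nothing at hand explains this step.

The step changes the substituent and its place on the aryl ring at once, and 3-chlorophenyl and 4-methylphenyl on the same core would be needed to tell those two changes apart. On these data alone, it also remains open whether a methoxy group or a nitrile on the aryl ring would keep the read-out on this core, and whether the methoxy on the chain would raise it here as well.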